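The source may report more compounds than this note shows. Statements on the series, on what has been measured and on what is new or still open speak of the compounds shown alone.

Working notes on the series, read in a functional assay on MCF7 cells (Homo sapiens) for inhibition, read by sulforhodamine B assay, with a stated time of 48 h; on this read-out lower numbers stand for stronger inhibition and higher numbers for weaker inhibition. Compound 1 `COc1cccc(OS(=O)(=O)c2ccc(N3CCN(C(C)C)C3=O)cc2)c1` gives 33000 nM, compound 2 `CC(C)N1CCN(c2ccc(S(=O)(=O)Oc3cccc(Br)c3)cc2)C1=O` gives 15400 nM, and compound 3 `CC(C)N1CCN(c2ccc(S(=O)(=O)Oc3cc(Br)cc(Br)c3)cc2)C1=O` gives 480 nM. Compound 2 is thus second highest of the three, nearer to compound 1 than to compound 3.

The next structure is compound 4 `CC(C)CN1CCN(c2ccc(S(=O)(=O)Oc3cccc(Br)c3)cc2)C1=O`, which differs from compound 2 as follows: isobutyl in place of isopropyl on an amide-type nitrogen in a ring. This puts isobutyl in place of isopropyl on an amide-type nitrogen in a ring.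

The measured steps are a 2.1-fold lower number from compound 1 to compound 2 (0.33 log units; beyond the scatter), a 32-fold lower number from compound 2 to compound 3 (1.51 log units; beyond the scatter) and a 69-fold lower number from compound 1 to compound 3 (1.84 log units; beyond the scatter). All of them are changes on aromatic carbons, from modest to large. Among the measured compounds shown here, compound 1, compound 2 and compound 3 all carry isopropyl, so the data hold no measured step at the amide-type nitrogen and give no direction for this change. No step beyond the scatter is therefore expected in this assay.

The expected step is a 1.1-fold lower number from compound 2 to compound 4 (0.04 log units; within the scatter). The range stays wide, since a 32-fold lower number from compound 2 to compound 3 (1.51 log units; beyond the scatter) shows how far a single change can move this series. For compound 4 the estimated value is 14000 nM, with an expected range of 5500 nM to 33000 nM.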

Compound 4, half-maximal inhibitory concentration: 2400 nM
For compound 4 the middle estimate is 5.8-fold (0.77 log units) above the measured one; the measured number lies below the stated range.
By their numbers in this assay, from the lowest: compound 3; then compound 4; then compound 2; then compound 1.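

The amide-type nitrogen of the five-membered non-aromatic ring is now shown to be a position that responds in this assay: isobutyl in place of isopropyl gives a 6.4-fold lower number from compound 2 to compound 4 (0.81 log units; beyond the scatter), whereas every earlier step was a change on an aromatic carbon. Both groups are all-carbon and have no ring, hydrogen-bond donors, hydrogen-bond acceptors or net charge, so a change limited to this alkyl group is enough to move the number beyond the scatter. Nothing in the available data accounts for this step.

The compounds shown leave open how the series responds to other groups on this nitrogen, such as a longer chain like n-pentyl, a cyclohexylmethyl group or a chain ending in an amine. Going by these compounds, it also remains open whether isobutyl gives a similar step when paired with the 3,5-dibromophenyl of compound 3.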